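Replacing the isobutyl arm on the benzoxazolone series

The compounds below may be only part of what the source reports. "The series", "measured", "known", "first", "only" and "open" are said of these compounds alone.

Measured so far:
Compound 1, `CC(C)Cc1cc2oc(=O)n(CCC(=O)O)c2cc1Cl`: 794 nM
Compound 2, `C[C@@H](Oc1cc2onc(CCC(=O)O)c2cc1Cl)c1ccc(F)cn1`: 31.6 nM

In an assay on HEK293 cells for inhibition of kynurenine 3-monooxygenase (Homo sapiens), read by LC-MS, with a stated time of 20 h (a higher number here means a weaker inhibitor, a lower number a stronger inhibitor), compound 1 gives the highest of the two numbers; its nearest neighbour, compound 2, gives a number beyond the scatter lower. Compound 2 differs from compound 1 in the core as well as in the side arm, so the two values show only that the arylalkoxy side arm with a different core reaches much lower numbers. Compound 3, `C[C@@H](Oc1cc2oc(=O)n(CCC(=O)O)c2cc1Cl)c1ncco1`, keeps the core of compound 1 and changes one place: a group of 8 heavy atoms (5 carbon, 1 nitrogen, 2 oxygen; one five-membered aromatic ring with 2 hetero atoms) in place of a group of 4 heavy atoms (4 carbon; no ring), on an aromatic carbon. Among the compounds with values here, with no step between measured compounds for this change, a downward step is expected, of moderate size. Compound 3 is estimated at 120 nM, within 30 nM to 500 nM, which corresponds to an expected step of a 6.6-fold lower number from compound 1 to compound 3 (0.82 log units; beyond the scatter).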

Compound 3, half-maximal inhibitory concentration: 7940 nM
Compound 3: the middle estimate sits 66-fold (1.82 log units) below what was measured; measured number above the stated range.
By their numbers in this assay, from the lowest: compound 2; then compound 1; then compound 3.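

On the core of compound 1, the isobutyl arm does not tolerate replacement by this group carrying a five-membered aromatic ring: in this assay the change gives a 10-fold higher number from compound 1 to compound 3 (1.00 log units; beyond the scatter). The position, on an aromatic carbon ortho to the chloro group, therefore responds to the arm, and here the larger group gives the weaker inhibitor. Nothing available accounts for this step.

Still open, as far as these compounds go, is whether the five-membered ring itself sets this loss, or whether a phenyl ring on the same arm would behave differently. The arm of compound 2 also remains to be read on the core of compound 1.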